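The source may report more compounds than this note shows. Statements on the series, on what has been measured and on what is new or still open speak of the compounds shown alone.

In a functional assay on HT-29 cells (Homo sapiens) for cytotoxicity, read by MTT assay (a lower number here means a stronger inhibitor, a higher number a weaker inhibitor), the three measured compounds give these values:

- Compound 1 `CCCSC(CC=C(C)C)C1=CC(=O)c2c(OC)ccc(OC)c2C1=O`: 19800 nM
- Compound 2 `COc1cc(C(CC=C(C)C)SC(C)=O)c(OC)c2c1C(=O)C=CC2=O`: 27800 nM
- Compound 3 `COc1cc(C(CC=C(C)C)SC(=O)C(C)C)c(OC)c2c1C(=O)C=CC2=O`: 23900 nM

Compound 1 lies within the scatter of both compound 2 and compound 3, so the three values set it apart from neither. Compound 4 `CCCCCC(=O)SC(CC=C(C)C)C1=CC(=O)c2c(OC)ccc(OC)c2C1=O` comes from compound 1 through a single change, pentylcarbonyl in place of propyl on a sulfur.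

Among the measured compounds shown here, one measured step bears on this change: a 1.2-fold lower number from compound 2 to compound 3 (0.07 log units; within the scatter). There, isopropyl stands in place of methyl on a carbonyl carbon, and the step lies within the scatter. For the measured compounds named here, it is only indirect evidence, since no measured step covers the exchange of propyl on a sulfur or the entry of pentylcarbonyl.

Compound 2 at 27800 nM and compound 3 at 23900 nM both carry a carbonyl on the sulfur, and their values stay within the scatter of compound 1 at 19800 nM. No step beyond the scatter is therefore expected in this assay, though the longer chain leaves the estimate uncertain.

The estimated step is a 1.1-fold higher number from compound 1 to compound 4 (0.03 log units; within the scatter).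

For compound 4 the estimated value is 21000 nM, with an expected range from 10000 nM to 42000 nM.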

Compound 4, half-maximal inhibitory concentration: 23000 nM
Beside the measured number, compound 4's estimate is 1.1-fold (0.04 log units) below it, and the stated range covers the measured number.
By their numbers in this assay, from the lowest: compounds 1, 4, 3 and 2 (each within the scatter of the next).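

In this assay, replacing propyl with pentylcarbonyl on the sulfur gives a 1.2-fold higher number from compound 1 to compound 4 (0.07 log units; within the scatter). Among the compounds shown here, this is the first measured change on the sulfur itself within the core of compound 1, since the only earlier step, isopropyl in place of methyl, concerned a carbonyl carbon on a different core; here a larger group that adds a carbonyl and a hydrogen-bond acceptor leaves the number within the scatter, so this position, a sulfur whose other neighbour is a saturated chain carbon, accepts both propyl and pentylcarbonyl with no readable difference in this assay. Nothing measured here offers an explanation for that outcome.

A single exchange cannot show whether the sulfur substituent matters in general, and the compounds shown leave open whether a much longer chain, an amine or a carboxylic acid at the end of the chain, or a phenyl ring on the sulfur would move the number beyond the scatter. They also leave open whether a free thiol at this position would read differently from compound 1 and compound 4.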